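The source may report more compounds than this note shows. Statements on the series, on what has been measured and on what is new or still open speak of the compounds shown alone.

Within the data shown here, compound 1, with the structure `CN1C(=O)C(O)(Cc2nnn[nH]2)c2ccccc21`, is the only compound in this set for which a number rather than a limit has been recorded. In a functional assay on PC-3 cells (Homo sapiens) for antiproliferative activity, read by MTT assay, with a stated time of 48 h (on this read-out higher numbers stand for weaker inhibition and lower numbers for stronger inhibition), compound 1 gives 44800 nM. Compound 2, with the structure `CCN1C(=O)C(O)(Cc2nnn[nH]2)c2ccccc21`, differs from it by methyl in place of hydrogen on a saturated chain carbon bound to an amide-type nitrogen in a ring. In this assay compound 2 reaches only a limit, > 100000 nM, which is the limit of > 100000 nM in this assay, at which 1 of the 2 values shown sits. Among the measured compounds shown here, the single measured step is therefore an at least 2.2-fold higher number from compound 1 to compound 2 (0.34 log units; beyond the scatter), a weakening.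

Compound 3, with the structure `CN1C(=O)C(O)(Cc2nnn[nH]2)c2cc(Br)ccc21`, keeps the methyl of compound 1 and differs from it elsewhere: bromo in place of hydrogen on an aromatic carbon. For the measured compounds named here, no measured step touches the aromatic ring, so the step from compound 1 to compound 2 gives no direct guide here, and the change to compound 3 is small in size. An expected step of a 1.1-fold lower number from compound 1 to compound 3 (0.05 log units; within the scatter) is therefore estimated, lying within the scatter. Compound 3 is expected to give about 40000 nM in this assay, estimated between 12000 nM and 130000 nM.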

Compound 3, half-maximal inhibitory concentration: > 100000 nM
Compound 3 ended at the assay's limit (the forecaster's own chance of this, stated with the estimate: 25%); middle value at least 2.5-fold (0.39 log units) from the limit.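

Putting bromo in place of hydrogen on an aromatic carbon gives an at least 2.2-fold higher number from compound 1 to compound 3 (0.34 log units; beyond the scatter) in this assay, so the weakening is no longer confined to the chain on the amide-type nitrogen: a change of 1 heavy atom on the six-membered aromatic ring also produces it. Compound 3 stands at a limit, > 100000 nM, and not at a number. Compound 1 therefore remains the only compound here with a number, and the single changes made to it, one on the chain and one on the aromatic ring, end at the same limit: the limit of > 100000 nM in this assay, at which 2 of the 3 values shown sit.

Going by these compounds, what stays open is whether this aromatic carbon resists substitution in general or the result belongs to bromo alone, a question that a fluoro, a chloro or a methoxy group at the same carbon would address. Also open, on these data alone, are how far compound 2 and compound 3 actually lie from compound 1, which of the two changes weakens more, and how a hydrogen in place of the methyl on the amide-type nitrogen would read in this assay.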